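Replacing an Amide Chain with Cyclopentyl: Expected Cytotoxicity

The source may hold more compounds than are shown below. What is called first, only, known or untested is meant among the compounds shown, and "the series" means these compounds.

Compound 1 `Nc1nc2ncccn2c1-c1ccc(Br)cc1` and compound 2 `CCNC(=O)CCCOc1ccc(-c2nc3ncccn3c2NC2CCCCC2)cc1` were both tested in a toxicity assay on A549 cells (Homo sapiens) for cytotoxicity, read by luminescence and CellTiter-Glo, with a stated time of 48 h; on this read-out higher numbers stand for lower toxicity in this test and lower numbers for higher toxicity in this test. In this assay compound 1 gives > 100000 nM, which is a limit of the assay and not a number. In this assay compound 2 gives > 100000 nM, again a limit and not a number. Compound 2 therefore stands at the limit of > 100000 nM in this assay, at which 2 of the 2 values shown sit, so nothing separates it from compound 1 on the numbers shown. Compound 3 `c1cnc2nc(-c3ccc(OC4CCCC4)cc3)c(NC3CCCCC3)n2c1` has not yet been measured. It differs from compound 2 in one place: cyclopentyl in place of 3-(ethylcarbamoyl)propyl on an oxygen on an aromatic ring. Going by the values given here, no measured step between compounds differing in one place is available here, so the size of the change must be expected rather than read off. The step is expected to be small, toward lower numbers in this assay and within the usual scatter: an at least 1.4-fold lower number from compound 2 to compound 3 (0.15 log units; that floor lies within the scatter). Compound 3 is thus estimated at 70000 nM, with a range from 20000 nM to 200000 nM.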

Compound 3, half-maximal cytotoxic concentration: 39000 nM
The estimate for compound 3 lay 1.8-fold (0.25 log units) above the measured number; measured number inside the range.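

In this assay, the group on this oxygen can change the read-out: cyclopentyl in place of 3-(ethylcarbamoyl)propyl gives an at least 2.5-fold lower number from compound 2 to compound 3 (0.40 log units; beyond the scatter). Compound 3 is the only one of the three with a number rather than a limit, so this single change is enough to bring cytotoxicity into the range the test can read. Going by these compounds, the true size of the step remains unknown because compound 2 gives only a limit of the assay: the limit of > 100000 nM in this assay, at which 2 of the 3 values shown sit.

On these data alone, it remains open whether losing the amide or gaining the ring sets the lower number, and a plain butyl chain on the same oxygen would help separate the two. As far as these compounds go, it is also open how an amine or a carboxylic acid at this place would move the number.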